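Hydroxypyridine in Place of Fluorophenyl on the Shared Core

This account rests on a few compounds, and the source may have more. Where it says the series, first, only, none or still open, it means among the compounds named here.

Of the compounds shown here, three have been measured in a functional assay on HEK293 cells for agonist activity at D(4) dopamine receptor (Homo sapiens), read by FLIPR; on this read-out higher numbers stand for larger maximal responses and lower numbers for smaller maximal responses. Compound 1 `Cc1cccc(NC(=O)CN2CCC(c3cccc(F)c3)CC2)c1` gives 40% in this assay. Compound 2 `c1ccc(C2CCN(Cc3nc4ccccc4[nH]3)CC2)nc1` gives 62% in this assay, and compound 3 `Cc1cc(Br)ccc1NC(=O)CN1CCC(c2cccc[n+]2[O-])CC1` gives 61% in this assay. Among these three numbers compound 1 stands lowest; its nearest neighbour is compound 3, whose value lies higher by a margin beyond the usual scatter, and the furthest is compound 2, whose value lies higher still, also beyond the scatter. Among the measured compounds shown here, no two of the measured compounds differ in a single place, so no isolated step between measured compounds is available, and any expectation must rest on the values themselves.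

Compound 4 `Cc1cccc(NC(=O)CN2CCC(c3ccc(O)cn3)CC2)c1` has not yet been measured in this assay. It differs from compound 1 in one place: 5-hydroxypyridin-2-yl in place of 3-fluorophenyl on a saturated ring carbon. For the measured compounds named here, nothing among the measured compounds isolates this exchange. The step of a number 17 percentage points higher from compound 1 to compound 4 (beyond the scatter) is expected to run upward by more than the scatter. This expectation rests on the low standing of compound 1, which gives 40% against the clearly higher values of compound 2 and compound 3. Compound 4 is therefore estimated to reach 57%, with a range from 35% to 80%.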

Compound 4, largest response reached (reported as efficacy), in percent of the reference or control that the assay uses: 83%
Compound 4: the middle estimate sits 26 percentage points below what was measured; the measured number lies above the stated range.
By their numbers in this assay, from the lowest: compound 1; then compounds 3 and 2 (each within the scatter of the next); then compound 4.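

In this assay, among the compounds shown here, the exchange of 3-fluorophenyl for 5-hydroxypyridin-2-yl on the saturated ring carbon gives a large step, a number 43 percentage points higher from compound 1 to compound 4 (beyond the scatter), and this is the only isolated change in the set. It shows that the position, three ring bonds from the ring nitrogen, is not indifferent to the group it carries: with the rest of compound 1 held fixed, the largest response moves well beyond the scatter. This happens although the entering and the leaving group have the same count of heavy atoms and neither carries a net charge, so the size of the group by that count does not account for the step. Nothing measured here explains why the response rises so far.

For the compounds shown here, the one step removes the fluorine and brings in the ring nitrogen and the hydroxy group together, so the share of each in the rise remains unresolved. On these data alone, whether a methoxy group or an amine in place of the hydroxy group on the same pyridine ring would keep the response at this level also remains open.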